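Fluoro gives way to methoxy at the assay limit

The source may hold more compounds than are shown below. What is called first, only, known or untested is meant among the compounds shown, and "the series" means these compounds.

Measured in an ADME assay on Vero cells (Chlorocebus sabaeus) for cytotoxicity, with a stated time of 5 days (a lower number here means a stronger inhibitor, a higher number a weaker inhibitor), as follows
- Compound 1 `COc1nc(NC2CC2)c2ncn([C@H]3C[C@H](N=[N+]=[N-])[C@@H](CO)O3)c2n1` gives > 100000 nM (a limit)
- Compound 2 `CNc1nc(Cl)nc2c1ncn2[C@H]1C[C@H](N=[N+]=[N-])[C@@H](CO)O1` gives > 100000 nM (a limit)
- Compound 3 `COc1nc(F)nc2c1ncn2[C@H]1C[C@H](N=[N+]=[N-])[C@@H](CO)O1` gives > 100000 nM (a limit)

Compound 3 stands at > 100000 nM in this assay and this is a limit, not a number. For the measured compounds named here, it has company, since all three compounds share the same mark (the limit of > 100000 nM in this assay, at which 3 of the 3 values shown sit) and no measured step exists among them. Going by the values given here, the series therefore offers no size of change to carry forward, only the fact that no compound has yet given a number.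

Compound 4 `COc1nc(OC)c2ncn([C@H]3C[C@H](N=[N+]=[N-])[C@@H](CO)O3)c2n1` differs from compound 3 in one place, with methoxy in place of fluoro on an aromatic carbon between two ring nitrogen atoms (methoxy in place of fluoro on an aromatic carbon). Compound 1 already carries methoxy on that aromatic carbon, and compound 1 reads > 100000 nM as a limit too.

The expected change is a number no higher from compound 3 to compound 4 (the limit leaves the size open) with no step beyond the scatter in either direction. Compound 4 is estimated at 100000 nM with an expected range from 40000 nM to 200000 nM and will most likely be reported only as a limit.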

Compound 4, half-maximal inhibitory concentration: > 100000 nM
Compound 4 ended at the assay's limit (the forecaster's own chance of this, stated with the estimate: 85%); the middle value lies on the limit itself.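

In this assay compound 4 gives > 100000 nM, which is a limit and not a number. Its steps from compound 3 and from compound 1 cannot be read, since those compounds stand at the same mark: the limit of > 100000 nM in this assay, at which 4 of the 4 values shown sit.

The compounds shown leave open how methoxy in place of fluoro affects the reading, as none of the four gives a number.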